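The source may report more compounds than this note shows. Statements on the series, on what has been measured and on what is new or still open speak of the compounds shown alone.

Measured compounds in a functional assay on SK-MEL-5 cells (Homo sapiens) for inhibition, read by sulforhodamine B assay, with a stated time of 48 h; on this read-out higher numbers stand for weaker inhibition of growth and lower numbers for stronger inhibition of growth:
compound 1, `Nc1cc(N)c2nc(-c3ccccc3)c(NCc3ccc(Cl)c(Cl)c3)nc2c1` — 10700 nM
compound 2, `COc1ccc(CNc2nc3cc(N)cc(N)c3nc2-c2ccccc2)cc1OC` — 27500 nM
compound 3, `Nc1cc(N)c2nc(-c3ccccc3)c(NCc3ccc(F)cc3)nc2c1` — 3630 nM

Compound 3 carries the lowest number of the three, and both steps towards it lie beyond the scatter: a 2.9-fold lower number from compound 1 to compound 3 (0.47 log units; beyond the scatter) and a 7.6-fold lower number from compound 2 to compound 3 (0.88 log units; beyond the scatter). Between the other two, a 2.6-fold higher number from compound 1 to compound 2 (0.41 log units; beyond the scatter) puts compound 2, the dimethoxy-bearing analogue, at the highest number of the set.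

Compound 4, `COc1ccc(CNc2nc3cc(N)cc(N)c3nc2-c2ccccc2)cc1`, is not yet measured. Relative to compound 3 the change is methoxy in place of fluoro on an aromatic carbon. Among the compounds with values here, the steps that bear on it are those involving compound 2: a 7.6-fold lower number from compound 2 to compound 3 (0.88 log units; beyond the scatter) shows that exchanging the 3,4-dimethoxyphenyl group for 4-fluorophenyl lowered the number substantially, and a 2.6-fold higher number from compound 1 to compound 2 (0.41 log units; beyond the scatter) shows that the dimethoxy compound also stands above the dichloro compound. Here only a single methoxy enters, para to a large group, in place of a single fluoro, so only part of that difference is expected to carry over. The expectation for this assay is therefore a modest rise in the number, of the order of a 2.5-fold higher number from compound 3 to compound 4 (0.39 log units; beyond the scatter), in the direction of weaker growth inhibition. Compound 4 is estimated at 9000 nM, within a range of 3500 nM to 25000 nM.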

Compound 4, concentration for total growth inhibition: 31600 nM
Beside the measured number, compound 4's estimate is 3.5-fold (0.55 log units) below it; measured number outside the range, above it.
By their numbers in this assay, from the lowest: compound 3; then compound 1; then compounds 2 and 4 (each within the scatter of the next).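

In this assay the second methoxy of compound 2 adds nothing that can be read (a 1.1-fold higher number from compound 2 to compound 4 (0.06 log units; within the scatter)), so the single methoxy named in the 4-methoxyphenyl group of compound 4 already matches the dimethoxy compound, and the earlier pair of compound 2 and compound 3 could not separate these two contributions. On this aromatic carbon, methoxy in place of fluoro is therefore a large change on its own (an 8.7-fold higher number from compound 3 to compound 4 (0.94 log units; beyond the scatter)), about the size of the full exchange of 3,4-dimethoxyphenyl for 4-fluorophenyl (a 7.6-fold lower number from compound 2 to compound 3 (0.88 log units; beyond the scatter)). Compound 4 also stands clear of the dichloro analogue (a 3.0-fold higher number from compound 1 to compound 4 (0.47 log units; beyond the scatter)), so across these four compounds both methoxy-bearing members carry higher numbers than both halogen-bearing ones, and none goes against this.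

The compounds shown leave open whether a hydroxyl, an amine or a longer alkoxy chain on this aromatic carbon would give a number nearer that of compound 3 or that of compound 4, and where the plain unsubstituted benzyl group falls. Nothing at hand explains the size of the methoxy step.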